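This account rests on a few compounds, and the source may have more. Where it says the series, first, only, none or still open, it means among the compounds named here.

Measured in an ADME assay on Raji cells (Homo sapiens) for cytotoxicity, read by CellTiter-Glo, with a stated time of 72 h; a higher number here means that more compound is needed for the effect, a lower number that less compound is needed:
- compound 1 `C[C@@H]1CC[C@H]2CC3C(=O)CC[C@@]31C2(C)C`: 26000 nM
- compound 2 `CC1=C2CC(C)(C)/C=C/C/C(C)=C\C3=C[C@H](C)C[C@]3(O2)C1=O`: 26000 nM

Compound 2 stands level with compound 1 in this assay, within the scatter. Compound 3 `CC1=C2CC(C)(C)/C=C/[C@@H](O)/C(C)=C\C3=C[C@H](C)C[C@]3(O2)C1=O` has hydroxy in place of hydrogen on a saturated ring carbon of compound 2: hydroxy in place of hydrogen on a saturated ring carbon. Within the data shown here, no measured pair here differs in one place, so the data give no precedent for this change. No step beyond the scatter is expected, in either direction, and the uncertainty is wide. The estimated step is a 1.1-fold lower number from compound 2 to compound 3 (0.03 log units; within the scatter). For compound 3 the expected value is 24000 nM, with an estimated range of 8000 nM to 70000 nM.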

Compound 3, half-maximal effective concentration: 26000 nM
Estimate against measurement, compound 3: 1.1-fold (0.03 log units) below; the measured number falls inside the stated range.
By their numbers in this assay, from the lowest: compounds 1, 2 and 3 (each within the scatter of the next).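

In this assay, among these compounds, the swap of hydrogen for hydroxy on this saturated ring carbon gives no change at the digits printed from compound 2 to compound 3 (within the scatter) and is the first one-place step. At this position, the added hydroxy leaves the read-out level, so this carbon can carry the group without a step beyond the scatter in this cytotoxicity read-out. No supporting measurement bears on this result.

Still open, going by these compounds, is whether an amine, a carboxylic acid or a longer chain on this carbon would also leave the number level. On these data alone, the opposite stereochemistry at the hydroxy-bearing carbon also remains open.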